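Sulfonamide series at the chemokine receptor: compound 3

The compounds below may be only part of what the source reports. "The series", "measured", "known", "first", "only" and "open" are said of these compounds alone.

Measured so far:
compound 1, `CC(=O)N1CCC(NS(=O)(=O)c2ccc(NC(=O)c3ccccc3C)c3ccccc23)CC1`, 6.7 nM
compound 2, `CNC(=O)N1CCC(NS(=O)(=O)c2ccc(NC(=O)c3ccccc3C)c3ccccc23)CC1`, 0.7 nM

In an assay on L1.2 cells for binding affinity to C-C chemokine receptor type 8 (Homo sapiens) (on this read-out lower numbers stand for stronger inhibition and higher numbers for weaker inhibition), compound 2 stands lowest of the two numbers, and its nearest neighbour is compound 1, a step of a 9.6-fold lower number from compound 1 to compound 2 (0.98 log units; beyond the scatter). Compound 3, `CCCC(=O)N1CCC(NS(=O)(=O)c2ccc(NC(=O)c3ccccc3C)c3ccccc23)C1`, is not yet measured. It differs from compound 2 by 1-(propylcarbonyl)pyrrolidin-3-yl in place of 1-(methylcarbamoyl)piperidin-4-yl on a sulfonamide nitrogen. For the measured compounds named here, the only step that bears on this is the one from compound 1 to compound 2, where a methylamino group in place of a methyl on the carbonyl carbon gave a 9.6-fold lower number from compound 1 to compound 2 (0.98 log units; beyond the scatter). Compound 3 goes back to a carbonyl carbon bearing only carbon, as in compound 1, and additionally changes the ring; on that account compound 3 is expected to move to a higher number in this assay, by about an 11-fold higher number from compound 2 to compound 3 (1.06 log units; beyond the scatter). The estimate for compound 3 is 8 nM, with a range from 2 nM to 35 nM.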

Compound 3, inhibition constant: 34.3 nM
The estimate for compound 3 lay 4.3-fold (0.63 log units) below the measured number; measured number inside the range.
By their numbers in this assay, from the lowest: compound 2; then compound 1; then compound 3.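

In this assay, 1-(propylcarbonyl)pyrrolidin-3-yl in place of 1-(methylcarbamoyl)piperidin-4-yl on the sulfonamide nitrogen gave a 49-fold higher number from compound 2 to compound 3 (1.69 log units; beyond the scatter), showing that this position does not tolerate the combined change of ring and carbonyl substituent without a large rise in the number. Set against 1-acetylpiperidin-4-yl, whose carbonyl also bears a carbon substituent, the same group gave a 5.1-fold higher number from compound 1 to compound 3 (0.71 log units; beyond the scatter), so the return to such a carbonyl does not account for the whole rise. Nothing shown here explains either step.

The compounds shown change ring size and carbonyl substituent together, leaving open how much of the rise belongs to each. A 1-(methylcarbamoyl)pyrrolidin-3-yl or a 1-(propylcarbonyl)piperidin-4-yl group on the same nitrogen would separate the two.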